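The source may hold more compounds than are shown below. What is called first, only, known or untested is meant among the compounds shown, and "the series" means these compounds.

For the measured compounds named here, in a functional assay on NCI-H1650 cells (Homo sapiens) for inhibition, read by sulforhodamine B assay, with a stated time of 3 days (on this read-out lower numbers stand for stronger inhibition and higher numbers for weaker inhibition), compound 1 `O=C1Nc2ccc(F)cc2/C1=C\C(=O)c1ccc(O)cc1F` gives 3460 nM and compound 2 `O=C1Nc2ccc(F)cc2/C1=C\C(=O)c1ccc(C2CCCCC2)cc1` gives 2730 nM, so compound 2 sits within the scatter of the only other measured value. Compound 3 `O=C1Nc2ccc([N+](=O)[O-])cc2/C1=C\C(=O)c1ccc(C2CCCCC2)cc1` has nitro in place of fluoro on an aromatic carbon, and the rest of compound 2 is unchanged. Going by the values given here, no measured pair varies this place, so the data give no direction. The expected change, none beyond the scatter in this assay, is a 1.1-fold lower number from compound 2 to compound 3 (0.04 log units; within the scatter). For compound 3 the estimate is 2500 nM, with an expected range of 800 nM to 8000 nM.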

Compound 3, half-maximal inhibitory concentration: 3860 nM
For compound 3 the middle estimate is 1.5-fold (0.19 log units) below the measured one, within the range that was stated.
By their numbers in this assay, from the lowest: compounds 2, 1 and 3 (each within the scatter of the next).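

For the compounds shown here, this is the first step that varies this aromatic carbon of the fused system: nitro in place of fluoro gives a 1.4-fold higher number from compound 2 to compound 3 (0.15 log units; within the scatter) in this assay on an otherwise unchanged structure. Nitro brings more heavy atoms and two hydrogen-bond acceptors, yet the number does not shift beyond the scatter at this one position. Nothing available explains this outcome.

Still open, on these data alone, is whether an amine or a carboxylic acid on this carbon would move the number beyond the scatter. A single step also leaves open whether the same exchange would read alike on the core of compound 1.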